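Changing the amide ring partner on a farnesyl thioether

The compounds below may be only part of what the source reports. "The series", "measured", "known", "first", "only" and "open" are said of these compounds alone.

Within the data shown here, compound 1 `CC(C)=CCC/C(C)=C/CC/C(C)=C/CSC[C@H](NC(=O)CCCCCN1CCN(C)CC1)C(=O)NC1CC1` gives 10400 nM in a functional assay on MIA PaCa-2 cells (Homo sapiens) for cytotoxicity, read by fluorescence, with a stated time of 48 h (a higher number here means that more compound is needed for the effect, a lower number that less compound is needed), the highest of the two numbers known. Among the measured compounds shown here, compound 2 `CC(C)=CCC/C(C)=C/CC/C(C)=C/CSC[C@H](NC(=O)CCCCCN1CCN(C)CC1)C(=O)NC1CCCCCC1` gives 2700 nM, and the step of a 3.9-fold lower number from compound 1 to compound 2 (0.59 log units; beyond the scatter) is the only measured change at this amide-type nitrogen. Compound 3 `CC(C)=CCC/C(C)=C/CC/C(C)=C/CSC[C@H](NC(=O)CCCCCN1CCN(C)CC1)C(=O)NC1CCCC1` has not been measured; it differs from compound 1 by cyclopentyl in place of cyclopropyl on an amide-type nitrogen. Since the step to compound 2 lowered the number when cyclopropyl gave way to another ring, a smaller lowering is expected here, a 2.1-fold lower number from compound 1 to compound 3 (0.32 log units; beyond the scatter), and compound 3 is estimated at 5000 nM, within 2500 nM to 10000 nM.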

Compound 3, half-maximal effective concentration: 10900 nM
Compound 3: the middle estimate sits 2.2-fold (0.34 log units) below what was measured; the whole stated range lies below it.
By their numbers in this assay, from the lowest: compound 2; then compounds 1 and 3 (each within the scatter of the next).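

In this assay the swap to cyclopentyl gives a 1.0-fold higher number from compound 1 to compound 3 (0.02 log units; within the scatter) and so no readable change, while the other new step is a 4.0-fold higher number from compound 2 to compound 3 (0.61 log units; beyond the scatter) and leaves cycloheptyl on its own. Across these three compounds, a larger ring on this amide-type nitrogen therefore does not steadily lower the number: cyclopentyl goes against that trend, and only compound 2 stands apart. No evidence is available to explain this. Where a cyclohexyl ring would fall remains open, as does the effect of an open-chain group such as tert-butyl or of a benzyl group at this nitrogen.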